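The source may hold more compounds than are shown below. What is called first, only, known or untested is meant among the compounds shown, and "the series" means these compounds.

The compounds measured so far, each in a functional assay on HeLa cells (Homo sapiens) for cytotoxicity, read by MTT assay, with a stated time of 24 h; a lower number here means a stronger inhibitor, a higher number a weaker inhibitor:

Compound 1, `C=CC1=C(C(=O)NCc2ccc(Cl)cc2)C(c2ccc(F)cc2)OC1`. In this assay compound 1 gives > 100000 nM, which is a limit of the assay rather than a number.
Compound 2, `C=CC1=C(C(=O)NCC(C)C)C(c2ccc(F)cc2)OC1`. Compound 2 gives > 100000 nM, again only a limit.
Compound 3, `C=CC1=C(C(=O)NC(C)(C)C)C(c2ccc(F)cc2)OC1`. Compound 3 gives > 100000 nM, also a limit.

Compound 3 thus stands where compounds 1 and 2 stand, at the limit of > 100000 nM in this assay, at which 3 of the 3 values shown sit. None of the three is separated from the others by a readable number. The changes on the amide-type nitrogen among them, the steps a step that the two limits leave unreadable from compound 1 to compound 2, a step that the two limits leave unreadable from compound 1 to compound 3 and a step that the two limits leave unreadable from compound 2 to compound 3, cannot be sized, since both ends of each sit at the limit.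

Compound 4, `C=CC1=C(C(=O)NC2CCCCC2)C(c2ccc(F)cc2)OC1`, is not yet measured. It differs from compound 3 in one place: cyclohexyl in place of tert-butyl on an amide-type nitrogen. All three measured steps concern the group on this same amide-type nitrogen, and all three are unreadable. There is therefore no measured basis for expecting a change beyond the scatter in this assay; the step from compound 3 to compound 4 is expected to be a step that the limit leaves unreadable from compound 3 to compound 4. For compound 4 the expected value is 150000 nM, with a range from 50000 nM to 600000 nM, most likely reported only as a limit.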

Compound 4, half-maximal inhibitory concentration: > 100000 nM
Compound 4: only a limit was reported; the forecaster's own chance of this, stated with the estimate: 85%; the middle value does not contradict the limit.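

In this assay compound 4 gives > 100000 nM, which is a limit and not a number. The steps to compound 4 from compound 1, compound 2 and compound 3 therefore cannot be read, with all four compounds at the same limit: the limit of > 100000 nM in this assay, at which 4 of the 4 values shown sit. The compounds shown leave open whether changing the group on the amide-type nitrogen alters the read-out at all.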